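The compounds below may be only part of what the source reports. "The series", "measured", "known", "first", "only" and "open" are said of these compounds alone.

Working notes on the series. Compound 1 `S=c1oc(-c2ccc3c(c2)OCCO3)nn1CN1CCN(c2cccc(Cl)c2Cl)CC1` carries a 2,3-dichlorophenyl on an amine nitrogen in a ring. In a functional assay on BGC-823 cells (Homo sapiens) for antiproliferative activity, read by MTT assay, with a stated time of 48 h (on this read-out higher numbers stand for weaker inhibition and lower numbers for stronger inhibition), compound 1 gives 22600 nM. Compound 3 `COc1ccc(N2CCN(Cn3nc(-c4ccc5c(c4)OCCO5)oc3=S)CC2)cc1` gives 18900 nM in this assay, so compound 1 holds the higher of the two numbers, with compound 3 nearest, and the step of a 1.2-fold lower number from compound 1 to compound 3 (0.08 log units; within the scatter) stays within the scatter. Compound 2 `Fc1ccc(N2CCN(Cn3nc(-c4ccc5c(c4)OCCO5)oc3=S)CC2)cc1` gives only > 50000 nM in this assay, which is a limit of the assay rather than a number. That value sits at the limit of > 50000 nM in this assay, at which 1 of the 3 values shown sits. The step of an at least 2.2-fold higher number from compound 1 to compound 2 (0.34 log units; beyond the scatter) and the step of an at least 2.6-fold lower number from compound 2 to compound 3 (0.42 log units; beyond the scatter) are the two that clear the scatter.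

Compound 4 `O=[N+]([O-])c1ccc(N2CCN(Cn3nc(-c4ccc5c(c4)OCCO5)oc3=S)CC2)cc1` is not yet measured. Relative to compound 1 the change is 4-nitrophenyl in place of 2,3-dichlorophenyl on an amine nitrogen in a ring. The two measured steps from compound 1, each replacing the 2,3-dichlorophenyl on an amine nitrogen in a ring, bear on it: one within the scatter, one at least modest toward a higher number. Nothing among the three compounds tests a 4-nitrophenyl directly, so only a small shift, if any beyond the scatter, is expected, with the risk of a limit as with compound 2. The expected step is a 1.2-fold higher number from compound 1 to compound 4 (0.06 log units; within the scatter). For compound 4 the estimate in this assay is 26000 nM, with a range from 12000 nM to 60000 nM.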

Compound 4, half-maximal inhibitory concentration: > 50000 nM
Compound 4 ended at the assay's limit; the forecaster's own chance of this, stated with the estimate: 30%; at least 1.9-fold (0.28 log units) between middle value and limit.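

The reading for compound 4 in this assay is a limit and not a number, so the limit is no longer a single case among the replacements at this position: the limit of > 50000 nM in this assay, at which 2 of the 4 values shown sit. The change from 2,3-dichlorophenyl to 4-nitrophenyl gives an at least 2.2-fold higher number from compound 1 to compound 4 (0.34 log units; beyond the scatter), so two of the three replacements of the 2,3-dichlorophenyl now move toward a higher number, and compound 3 goes against this, since its step from compound 1 stays within the scatter. On the same aromatic carbon, nitro in place of methoxy gives an at least 2.6-fold higher number from compound 3 to compound 4 (0.42 log units; beyond the scatter), which sets the methoxy of compound 3 apart from both the fluoro of compound 2 and the nitro of compound 4, although the step between those two limits cannot be read.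

The compounds shown give no order for fluoro and nitro, and they leave open whether a measurable number on this aromatic carbon is special to methoxy. An ethoxy, a hydroxyl or a dimethylamino group at the same place on the phenyl would test that directly.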